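Propoxy, benzyloxy, pentylsulfanyl: a chain replaced on a shared core

A few compounds are considered here, and "the series" means these few. Any claim that something is new, unique, unknown or untested is made for them only; others in the source may bear on it.

Compound 1 `CCCOc1nc(C(C)(C)C)ccc1CNC(=O)C(C)c1ccc(NS(C)(=O)=O)c(F)c1` gives 1.7 nM in an assay on cells for antagonist activity at transient receptor potential cation channel subfamily V member 1 (Homo sapiens), read by FLIPR and calcium flux, with a stated time of 6 min; a higher number here means a weaker inhibitor, a lower number a stronger inhibitor.
Compound 2 `CC(C(=O)NCc1ccc(C(C)(C)C)nc1OCc1ccccc1)c1ccc(NS(C)(=O)=O)c(F)c1` gives 4.4 nM in this assay.

For the measured compounds named here, compound 2 has the higher of the two numbers in this assay; the only step available, a 2.6-fold higher number from compound 1 to compound 2 (0.41 log units; beyond the scatter), is modest yet beyond the scatter. Compound 3 `CCCCCSc1nc(C(C)(C)C)ccc1CNC(=O)C(C)c1ccc(NS(C)(=O)=O)c(F)c1` differs from compound 2 by pentylsulfanyl in place of benzyloxy on an aromatic carbon. Going by the values given here, no measured step shows an oxygen replaced by sulfur, so the measured step bears on this change only loosely. A return toward the number of compound 1 is plausible, but a flat outcome within the scatter cannot be ruled out. Compound 3 is therefore expected to show a shift of a 1.5-fold lower number from compound 2 to compound 3 (0.17 log units; within the scatter), giving an estimate of 3 nM with a range of 1 nM to 10 nM.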

Compound 3, inhibition constant: 3.1 nM
Beside the measured number, compound 3's estimate is 1.0-fold (0.01 log units) below it; measured number inside the range.
By their numbers in this assay, from the lowest: compounds 1, 3 and 2 (each within the scatter of the next, the first and the last beyond it).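

Pentylsulfanyl has no ring and links through sulfur, yet the shift is a 1.4-fold lower number from compound 2 to compound 3 (0.15 log units; within the scatter) and the shift is a 1.8-fold higher number from compound 1 to compound 3 (0.26 log units; within the scatter) in this assay, so this position takes the sulfur-linked chain with neither step beyond the scatter. The linking atom and the chain change together in both steps, so the part played by sulfur alone cannot be separated. Nothing available explains this result.

Still open, going by these compounds, is how pentyloxy, the oxygen-linked form of the same chain, would compare with pentylsulfanyl. An amine at this position also remains untested among the compounds shown.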